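The compounds below may be only part of what the source reports. "The series", "measured", "known", "first", "only" and "open" are said of these compounds alone.

The measured compounds:
Compound 1 `O=C1C(NC2CCCC2)=CC(=O)c2c1nc1n2[C@H]2OC[C@@H](O)[C@H]2OC1`: in a functional assay on MGC-803 cells (Homo sapiens) for inhibition, read by sulforhodamine B assay (on this read-out higher numbers stand for weaker inhibition and lower numbers for stronger inhibition), compound 1 gives > 16000 nM, a limit of the assay rather than a number.
Compound 2 `O=C1C=C(Nc2ccccc2F)C(=O)c2c1nc1n2[C@H]2OC[C@@H](O)[C@H]2OC1`: in this assay compound 2 gives 2080 nM.
Compound 3 `O=C1C=C(NC2CCCC2)C(=O)c2c1nc1n2[C@H]2OC[C@@H](O)[C@H]2OC1`: in this assay compound 3 gives > 8000 nM, again a limit.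

Compound 1 therefore stands at the weak end of what was seen, known only as a limit (the limit of > 16000 nM in this assay, at which 1 of the 3 values shown sits), and compound 3 likewise sits at a limit (the limit of > 8000 nM in this assay, at which 1 of the 3 values shown sits). Among the compounds with values here, the one numbered result is compound 2.

Compound 4 `COc1ccc(NC2=CC(=O)c3c(nc4n3[C@H]3OC[C@@H](O)[C@H]3OC4)C2=O)cc1` differs from compound 1 by 4-methoxyphenyl in place of cyclopentyl on an amine nitrogen. The step that bears on this is the swap between compound 2 and compound 3, cyclopentyl in place of 2-fluorophenyl on an amine nitrogen, which gave an at least 3.8-fold higher number from compound 2 to compound 3 (0.58 log units; beyond the scatter). The change from compound 1 to compound 4 runs the other way, an aromatic group replacing cyclopentyl on the amine nitrogen, so a lower number, that is stronger inhibition, is expected, though compound 1 being a limit makes the size uncertain.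

For compound 4 the expected result in this assay is 3500 nM, in the range 900 nM to 16000 nM, an estimated step of an at least 4.5-fold lower number from compound 1 to compound 4 (0.66 log units; beyond the scatter).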

Compound 4, half-maximal inhibitory concentration: 2150 nM
Compound 4: middle estimate off by 1.6-fold (0.21 log units), on the high side; the range from low to high includes it.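

In this assay, putting 4-methoxyphenyl in place of cyclopentyl on the amine nitrogen gives an at least 7.4-fold lower number from compound 1 to compound 4 (0.87 log units; beyond the scatter) and so brings this compound into the measurable range. This is the second pair in which an aromatic ring on that nitrogen goes with the lower number, after the earlier swap in the opposite direction, which gave an at least 3.8-fold higher number from compound 2 to compound 3 (0.58 log units; beyond the scatter) with 2-fluorophenyl as the aromatic group; among the compounds shown, none goes against this pattern, although it rests on only these two pairs. The new step gives only a minimum size, since compound 1 is known solely as a limit of the assay: the limit of > 16000 nM in this assay, at which 1 of the 4 values shown sits.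

The compounds shown cannot separate the contribution of the aromatic ring from that of its methoxy group, and a plain phenyl group on the same nitrogen would be the direct test. As far as these compounds go, it also remains open whether a benzyl group, which sets the ring one carbon further from the nitrogen, or a simple open chain such as butyl would behave like the aromatic groups or like cyclopentyl.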